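The source may report more compounds than this note shows. Statements on the series, on what has been measured and on what is new or still open speak of the compounds shown alone.

Compound 1 `N#CCOc1ccc2c(c1)CCc1c-2c2c(c3c4ccccc4n(CCO)c13)CNC2=O` has the higher number of the two compounds already measured: in an assay on isolated protein for inhibition of mitogen-activated protein kinase kinase kinase 9 (Homo sapiens), tested at 1 uM (a higher number here means more inhibition at the concentration tested (going by the name of the read-out), a lower number less inhibition), compound 1 gives 30%. Compound 2 `O=C1NCc2c1c1c(c3[nH]c4ccccc4c23)CCc2cc(O)ccc2-1` gives 9% in this assay, a gap beyond the usual scatter. The next compound, compound 3 `O=C1NCc2c1c1c(c3c2c2ccccc2n3CCO)CCc2cc(OCc3ccccn3)ccc2-1`, differs from compound 1 in one place: pyridin-2-yl in place of cyano on a saturated chain carbon bound to an oxygen on an aromatic ring. For the measured compounds named here, no measured pair carries this same change, so the direction rests on the two numbers alone. A small gain is expected, with the step of a number 10 percentage points higher from compound 1 to compound 3 (within the scatter) in this assay possibly staying within the scatter. For compound 3 the expected result in this assay is 40%, within 15% to 65%.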

Compound 3, a percentage reported as inhibition, at one concentration (the size of the read-out at that concentration, not a potency): 36%
The estimate for compound 3 lay 4 percentage points above the measured number; low and high end bracket the measured number.
By their numbers in this assay, from the lowest: compound 2; then compounds 1 and 3 (each within the scatter of the next).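

Swapping the small cyano for the much larger pyridin-2-yl, which brings six heavy atoms and an aromatic ring in place of two heavy atoms and no ring, leaves this assay within the scatter, with a number 6 percentage points higher from compound 1 to compound 3 (within the scatter). So this carbon on the oxygen-bound chain accepts either group without a clear shift in the number. No measurement here offers an explanation for this.

Going by these compounds, it remains open whether a phenyl, an amine or a carboxylic acid in the same place would give a similar number, and how a longer chain would behave.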